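Removing chloro from the aryl group: second instance in series

The source may report more compounds than this note shows. Statements on the series, on what has been measured and on what is new or still open speak of the compounds shown alone.

Measured so far:
Compound 1 `COc1ccc(-c2nc(C)c(C(=O)CSc3nc(N)c(C#N)c(-c4ccc(Cl)cc4)n3)s2)cc1`: 44% in a functional assay on U-87MG ATCC cells for antiproliferative activity against U-87 MG (Homo sapiens), read by MTT assay, with a stated time of 48 h, tested at 10 uM; a higher number here means a weaker effect of the compound at the concentration tested, a lower number a stronger effect.
Compound 2 `COc1ccc(-c2nc(C)c(C(=O)CSc3nc(N)c(C#N)c(-c4ccccc4)n3)s2)cc1`: 57.8% in this assay.
Compound 3 `Cc1nc(-c2ccccc2)sc1C(=O)CSc1nc(-c2cccc(Cl)c2)c(C#N)c(=O)[nH]1`: 83.7% in this assay.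

Compounds 1 and 2 share one core; compound 3 has another core, and the difference between the two cores is not broken down here. Within the first core the change hydrogen in place of chloro on an aromatic carbon gave a number 13.8 percentage points higher from compound 1 to compound 2 (beyond the scatter).

Compound 4 `Cc1nc(-c2ccccc2)sc1C(=O)CSc1nc(-c2ccccc2)c(C#N)c(=O)[nH]1` is not yet measured. It differs from compound 3 by hydrogen in place of chloro on an aromatic carbon. This is the same kind of change as that from compound 1 to compound 2, but not the same: in compound 1 the chloro sits para to a large group, in compound 3 meta to a large group, and the cores differ.

Compound 3 already stands highest of the three in this assay. If the step repeats, compound 4 is expected to move by a number 11.3 percentage points higher from compound 3 to compound 4 (beyond the scatter), resting on the step from compound 1 to compound 2 and on the value of compound 3, which leaves little room before the ceiling of the read-out. Compound 4 is therefore estimated at 95%, within 80% to 105%.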

Compound 4, a percentage reported as activity, at one concentration (the size of the read-out at that concentration, not a potency): 87.5%
Compound 4: the middle estimate sits 7.5 percentage points above what was measured; measured number inside the range.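

In this assay, replacing chloro with hydrogen on the core of compound 3, the change from 3-chlorophenyl to phenyl, gives a number 3.8 percentage points higher from compound 3 to compound 4 (within the scatter). Set beside the earlier step, the result on this core does not differ measurably from that on the first: the same change on two cores in this assay, a number 13.8 percentage points higher (beyond the scatter) from compound 1 to compound 2 and a number 3.8 percentage points higher (within the scatter) from compound 3 to compound 4, 10 percentage points apart, within the scatter of two such steps The two steps are thus compatible with a change that carries across the two cores, but they do not establish a shared size, as only the first lies beyond the scatter, and the place of the chloro on the aryl group differs along with the core.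

Still open, as far as these compounds go, is whether the place of the chloro or the core matters more, a question that 3-chlorophenyl on the core of compound 1 and 4-chlorophenyl on the core of compound 3 would address. Also open, from the compounds shown here alone, is how fluoro, bromo or an amine at the place of the chloro would read in this assay on either core.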